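The source may hold more compounds than are shown below. What is called first, only, known or untested is meant among the compounds shown, and "the series" means these compounds.

Working notes on the series in a functional assay on B16-F10 cells (Mus musculus) for antiproliferative activity, read by MTT assay, with a stated time of 48 h; a lower number here means a stronger inhibitor, a higher number a weaker inhibitor: compound 1 (`CCCCCCCCCCCCOc1ccc(C(=O)/C=C/c2c(/C=C/c3ccc(OC)cc3)cc(OC)cc2OC)cc1`) gives 12.7 ug/mL, compound 2 (`CCCC(C)Oc1ccc(C(=O)/C=C/c2c(/C=C/c3ccc(OC)cc3)cc(OC)cc2OC)cc1`) gives 6.7 ug/mL and compound 3 (`COc1ccc(/C=C/c2cc(OC)cc(OC)c2/C=C/C(=O)c2cccc(Br)c2)cc1`) gives 5.1 ug/mL. Compound 3 is not separated from compound 2, and its number lies beyond the scatter under that of compound 1. Compound 4 (`COc1ccc(/C=C/c2cc(OC)cc(OC)c2/C=C/C(=O)c2ccc(Br)cc2)cc1`) changes one place, on a carbonyl carbon: 4-bromophenyl in place of 3-bromophenyl on a carbonyl carbon. Among the measured compounds shown here, no measured step tests this exchange directly. The closest, a 1.3-fold lower number from compound 2 to compound 3 (0.12 log units; within the scatter), concerns the same carbonyl carbon, and the other, a 1.9-fold lower number from compound 1 to compound 2 (0.28 log units; within the scatter), lies elsewhere. Both stay within the scatter, so no step beyond the scatter is expected in this assay. The estimate amounts to a 1.1-fold higher number from compound 3 to compound 4 (0.03 log units; within the scatter), in no clear direction. Compound 4 is expected at 5.5 ug/mL, with an estimated range of 2.8 ug/mL to 10.5 ug/mL.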

Compound 4, half-maximal inhibitory concentration: 6.5 ug/mL
The estimate for compound 4 lay 1.2-fold (0.07 log units) below the measured number; low and high end bracket the measured number.
By their numbers in this assay, from the lowest: compounds 3, 4, 2 and 1 (each within the scatter of the next, the first and the last beyond it).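

In this assay, 4-bromophenyl in place of 3-bromophenyl on the carbonyl carbon gives no separable change (a 1.3-fold higher number from compound 3 to compound 4 (0.11 log units; within the scatter)), so this exchange of two bromophenyl groups is not resolved by the assay. Bromo in place of 1-methylbutoxy on an aromatic carbon likewise stays within the scatter (a 1.0-fold lower number from compound 2 to compound 4 (0.01 log units; within the scatter)). No available evidence bears on either result. On these data alone, whether an amine or a carboxylic acid in place of bromo on that aromatic carbon would give a step beyond the scatter remains open.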